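The source may hold more compounds than are shown below. What is called first, only, known or untested is meant among the compounds shown, and "the series" means these compounds.

Of the compounds shown here, three sharing one core have been tested in a functional assay on HCT-116 cells (Homo sapiens) for inhibition; a lower number here means a stronger inhibitor, a higher number a weaker inhibitor. Compound 1 `C=CC(=O)OCc1cc(=O)oc2cc(OC)c(OC)cc12`, with vinyl on a carbonyl carbon, gives > 10 ug/mL, which is a limit of the assay and not a number. Compound 2 `C/C=C/C(=O)OCc1cc(=O)oc2cc(OC)c(OC)cc12`, with prop-1-en-1-yl in that place, gives > 10 ug/mL, again a limit. Compound 3 `COc1cc2oc(=O)cc(COC(=O)/C=C/c3ccccc3)c2cc1OC`, with 2-phenylethenyl there, gives > 10 ug/mL, also a limit. Compound 3 therefore has no number of its own and stands with the rest of the set: the limit of > 10 ug/mL in this assay, at which 3 of the 3 values shown sit.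

Compound 4 `COc1ccc(/C=C/C(=O)OCc2cc(=O)oc3cc(OC)c(OC)cc23)cc1` differs from compound 3 in one place: methoxy in place of hydrogen on an aromatic carbon. Methoxy stands in place of hydrogen on an aromatic carbon, turning phenyl into 4-methoxyphenyl.

The nearest measured changes are a step that the two limits leave unreadable from compound 1 to compound 2, a step that the two limits leave unreadable from compound 1 to compound 3 and a step that the two limits leave unreadable from compound 2 to compound 3. None of them adds a group to the phenyl and none has a readable size, so they support no particular size or direction for the new change. The expectation leans on compound 3, whose > 10 ug/mL is only a limit. In this assay the expected change is small, a step that the limit leaves unreadable from compound 3 to compound 4, with no clear gain in strength. Compound 4 is estimated at 15 ug/mL, with an expected range of 6 ug/mL to 40 ug/mL.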

Compound 4, half-maximal inhibitory concentration: 1.02 ug/mL
The estimate for compound 4 lay 15-fold (1.17 log units) above the measured number; the whole stated range lies above it.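

The first clear signal in this set comes from a single small addition on the phenyl ring: in this assay, methoxy in place of hydrogen on an aromatic carbon, which turns phenyl into 4-methoxyphenyl, gives an at least 9.8-fold lower number from compound 3 to compound 4 (0.99 log units; beyond the scatter). For the compounds shown here, replacing the methyl of compound 2 with 4-methoxyphenyl gives an at least 9.8-fold lower number from compound 2 to compound 4 (0.99 log units; beyond the scatter), whereas the steps among compounds 1, 2 and 3 cannot be read, so the earlier compounds showed no effect of changing this part of the ester, in either direction. Compound 4 is therefore the only compound shown that carries a true number, and both steps give only the least possible size of the gain, because the other three compounds stop at a limit: the limit of > 10 ug/mL in this assay, at which 3 of the 4 values shown sit.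

Going by these compounds, what remains open is whether the gain belongs to methoxy itself, or whether a hydroxyl, a fluorine or a dimethylamino group on the same aromatic carbon would do the same. It is also unclear whether a longer chain such as ethoxy would keep the gain, and with only one such compound shown, no trend across substituents on the phenyl can yet be drawn.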